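The source may hold more compounds than are shown below. What is called first, only, known or untested is meant among the compounds shown, and "the series" means these compounds.

Measured compounds in a functional assay on CHO cells for agonist activity at Alpha-2C adrenergic receptor (Homo sapiens); a higher number here means a larger maximal response, a lower number a smaller maximal response:

Compound 1, `COc1ccc(S(C)(=O)=O)c(NCC2=NCCN2)c1`: 49%
Compound 2, `CS(=O)(=O)c1ccc(F)cc1NCC1=NCCN1`: 91%
Compound 3, `CS(=O)(=O)c1ccc(Cl)cc1NCC1=NCCN1`: 81%

Compound 3 stands second highest of the three numbers in this assay. Its nearest neighbour is compound 2, a step of a number 10 percentage points lower from compound 2 to compound 3 (within the scatter), so the two are not separated. Compound 1 lies furthest off: a number 32 percentage points higher from compound 1 to compound 3 (beyond the scatter), and likewise a number 42 percentage points higher from compound 1 to compound 2 (beyond the scatter).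

Compound 4 is `CS(=O)(=O)c1ccc(C(F)(F)F)cc1NCC1=NCCN1`. It differs from compound 3 at the same aromatic carbon that carries the varied group in all three measured compounds: trifluoromethyl in place of chloro on an aromatic carbon.

Among the measured compounds shown here, the steps that bear on this change are the two exchanges at that carbon. Replacing methoxy by a halogen raised the maximal response strongly in both cases, whereas the exchange of one halogen for the other stayed within the scatter. For the measured compounds named here, no measured step introduces trifluoromethyl, so the direction is not fixed by the data; the two halogen compounds suggest the response at this position does not depend sharply on the small group present once methoxy is gone.

Compound 4 is therefore expected to give about 75%, with a range from 50% to 95%. The expected step of a number 6 percentage points lower from compound 3 to compound 4 (within the scatter) is estimated to lie within the scatter.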

Compound 4, largest response reached (reported as maximum), in percent of the reference or control that the assay uses: 25%
Beside the measured number, compound 4's estimate is 50 percentage points above it; measured number below the stated range.
By their numbers in this assay, from the lowest: compound 4; then compound 1; then compounds 3 and 2 (each within the scatter of the next).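

In this assay this aromatic carbon, para to a methylsulfonyl group, does not tolerate every small group once methoxy is gone, as the halogen pair alone might have suggested: the exchange for trifluoromethyl gives a number 56 percentage points lower from compound 3 to compound 4 (beyond the scatter) and a number 66 percentage points lower from compound 2 to compound 4 (beyond the scatter). Trifluoromethyl also falls short of methoxy, the lowest group until now, with a number 24 percentage points lower from compound 1 to compound 4 (beyond the scatter), so compound 4 stands lowest of the four, with its steps to all the others beyond the scatter. Nothing available here accounts for this drop.

Still open, from the compounds shown here alone, is whether the loss is peculiar to trifluoromethyl or extends to other groups at this carbon, such as a nitrile, a methyl or an amine. Also open, going by these compounds, is whether bromo would stay with compound 2 and compound 3 or fall towards compound 4.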